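A few compounds are considered here, and "the series" means these few. Any claim that something is new, unique, unknown or untested is made for them only; others in the source may bear on it.

Compound 3, whose structure is `O=C(NCc1ccc(OC(F)(F)F)c(Cl)c1)c1ccc(S(=O)(=O)Nc2cncnc2)c(F)c1`, stands at the edge of the numbers shown: in an assay on cells for inhibition of sodium channel protein type 3 subunit alpha (Homo sapiens), read by electrophysiology (a higher number here means a weaker inhibitor, a lower number a stronger inhibitor), compound 3 gives only a limit, > 3000 nM, and no number. Its two companions share the core of compound 3 and differ only at the sulfonamide nitrogen. Compound 1, `O=C(NCc1ccc(OC(F)(F)F)c(Cl)c1)c1ccc(S(=O)(=O)Nc2nccs2)c(F)c1`, gives 11 nM in this assay. Compound 2, `O=C(NCc1ccc(OC(F)(F)F)c(Cl)c1)c1ccc(S(=O)(=O)Nc2ncccn2)c(F)c1`, gives 374 nM in this assay. The measured steps are all large: a 34-fold higher number from compound 1 to compound 2 (1.53 log units; beyond the scatter), an at least 270-fold higher number from compound 1 to compound 3 (2.43 log units; beyond the scatter) and an at least 8.0-fold higher number from compound 2 to compound 3 (0.90 log units; beyond the scatter). The last of these rests on the limit recorded for compound 3 (the limit of > 3000 nM in this assay, at which 1 of the 3 values shown sits).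

Compound 4, `O=C(NCc1ccc(OC(F)(F)F)c(Cl)c1)c1ccc(S(=O)(=O)Nc2cccnn2)c(F)c1`, is the next step, with pyridazin-3-yl in place of pyrimidin-5-yl on a sulfonamide nitrogen. The two pyrimidinyl groups already show that the pattern of ring nitrogens within the same six-membered ring moves this assay strongly, as the step from compound 2 to compound 3 bears on it. A pyridazin-3-yl ring is therefore expected to bring compound 4 back into the measurable range: the step is estimated as an at least 5.0-fold lower number from compound 3 to compound 4 (0.69 log units; beyond the scatter), and the value for compound 4 is estimated at 600 nM, within 150 nM to 3000 nM.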

Compound 4, half-maximal inhibitory concentration: 1790 nM
For compound 4 the middle estimate is 3.0-fold (0.47 log units) below the measured one, within the range that was stated.
By their numbers in this assay, from the lowest: compound 1; then compound 2; then compound 4. At a limit, above all of these: compound 3.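

With the same count of atoms as the two pyrimidinyl groups, the pyridazin-3-yl group on the sulfonamide nitrogen gives a third distinct result in this assay, with a 4.8-fold higher number from compound 2 to compound 4 (0.68 log units; beyond the scatter), so the arrangement of ring nitrogens again moves the number beyond the scatter. This six-membered ring also stays far from the 1,3-thiazol-2-yl group, with a 160-fold higher number from compound 1 to compound 4 (2.21 log units; beyond the scatter). Compound 3 remains a limit and not a number, so an at least 1.6-fold lower number from compound 3 to compound 4 (0.22 log units; that floor lies within the scatter) gives only a floor, and how far compound 4 stands from compound 3 depends on this limit: the limit of > 3000 nM in this assay, at which 1 of the 4 values shown sits.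

On these data alone, the true size of that last step remains open. So does whether a pyridinyl or an oxazolyl ring on the sulfonamide nitrogen would stand nearer to compound 1 or to the six-membered rings shown here.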